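This account rests on a few compounds, and the source may have more. Where it says the series, first, only, none or still open, it means among the compounds named here.

In a functional assay on T98G cells (Homo sapiens) for inhibition, read by colorimetric assay and MTT assay, with a stated time of 72 h (on this read-out lower numbers stand for stronger inhibition and higher numbers for weaker inhibition), compound 1 `C=CCCCCOc1ccccc1-c1cnc(OCCC=C)n1C` gives 29000 nM and compound 3 `C=CCCCCOc1ccccc1-c1cnc(S(=O)(=O)c2ccccc2)n1C` gives 71000 nM, the higher of these two numbers. Compound 2 `Cn1c(-c2ccccc2O)cnc1S(=O)(=O)c1ccccc1` reads > 100000 nM, which is a limit of the assay and not a number. Compound 4 `C=CCCOc1ccccc1-c1cnc(S(=O)(=O)c2ccccc2)n1C` trims the chain of compound 3, turning hex-5-en-1-yl into but-3-en-1-yl: vinyl in place of but-3-en-1-yl on a saturated chain carbon, two bonds along the chain from an oxygen on an aromatic ring. The closest evidence is an at least 1.4-fold lower number from compound 2 to compound 3 (0.14 log units; that floor lies within the scatter), where the whole chain is added to the oxygen. The other step, a 2.4-fold higher number from compound 1 to compound 3 (0.39 log units; beyond the scatter), changes a different group and says little about chain length. A change beyond the scatter is therefore not expected in this assay, though the number may drift slightly higher. The expected step is a 1.1-fold higher number from compound 3 to compound 4 (0.05 log units; within the scatter). Compound 4 is estimated at 80000 nM, with an expected range of 45000 nM to 140000 nM.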

Compound 4, half-maximal inhibitory concentration: > 100000 nM
Compound 4 was reported as a limit; the forecaster's own chance of this, stated with the estimate: 30%; at least 1.2-fold (0.09 log units) between middle value and limit.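

In this assay, on these data alone, trimming hex-5-en-1-yl to but-3-en-1-yl gives an at least 1.4-fold higher number from compound 3 to compound 4 (0.14 log units; that floor lies within the scatter), so the shorter chain brings no stronger inhibition, although the true size of this step stays unknown. Compound 4 reads as a limit, the same one as compound 2: the limit of > 100000 nM in this assay, at which 2 of the 4 values shown sit. The step from compound 2 to compound 4 joins two limits and cannot be read. As far as these compounds go, what stays open is how a chain longer than hex-5-en-1-yl, or an amine in its place, would read on an oxygen on an aromatic ring.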